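Benzyl purines: chloro to amino on the core

This account rests on a few compounds, and the source may have more. Where it says the series, first, only, none or still open, it means among the compounds named here.

Measured so far:
compound 1 `ClCc1ccccc1Cn1cnc2c(Cl)nc(Cl)nc21` — 4780 nM
compound 2 `ClCc1ccc(Cn2cnc3nc(Cl)nc(Cl)c32)cc1` — 23400 nM

In a functional assay on A498 cells (Homo sapiens) for cytotoxicity, read by sulforhodamine B assay, with a stated time of 48 h (a lower number here means a stronger inhibitor of growth, a higher number a weaker inhibitor of growth), compound 1 gives 4780 nM and holds the lower of the two numbers; compound 2 gives 23400 nM, a gap beyond the scatter. Compound 3 `Nc1nc(Cl)c2ncn(Cc3ccccc3CCl)c2n1` keeps the core of compound 1 and differs in one place: amino in place of chloro on an aromatic carbon, between two ring nitrogen atoms. Within the data shown here, no measured pair shows this change, so its size is unknown; a weakening of modest size is expected. For compound 3 the expected value is 12000 nM (range 4000 nM to 40000 nM), an expected step of a 2.5-fold higher number from compound 1 to compound 3 (0.40 log units; beyond the scatter).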

Compound 3, concentration for total growth inhibition: 44700 nM
Compound 3: middle estimate off by 3.7-fold (0.57 log units), on the low side, outside the stated range (above it).
By their numbers in this assay, from the lowest: compound 1; then compounds 2 and 3 (each within the scatter of the next).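

In (this assay), amino in place of chloro on an aromatic carbon, between two ring nitrogen atoms, weakens growth inhibition (a 9.4-fold higher number from compound 1 to compound 3 (0.97 log units; beyond the scatter)). Among these compounds, this is the first one-place change measured, and it shows that this chloro group cannot be exchanged for amino without a loss beyond the scatter. Nothing available on these compounds explains the step. Still open, as far as these compounds go, is whether a methylamino or methoxy group here would track amino or chloro, and whether the same change on compound 2 gives a step of similar size.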